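Swapping a Pyridinylmethyl for a Methylphenyl Group

The source may hold more compounds than are shown below. What is called first, only, known or untested is meant among the compounds shown, and "the series" means these compounds.

Of the compounds shown here, three share one core and have been measured in a physicochemical assay for solubility; a lower number here means a less soluble compound, a higher number a more soluble compound. Compound 1, `N#Cc1ncc(-n2c(=O)n(Cc3ccccc3)c3ccccc32)cc1C(F)(F)F`, gives 5300 nM. Compound 2, `N#Cc1ccc(-n2c(=O)n(Cc3cccnc3)c3ccccc32)cc1C(F)(F)F`, gives 2500 nM, the lowest of the two plain numbers; the gap to compound 1 lies beyond the usual scatter of repeated measurements. Compound 3, `N#Cc1ccc(-n2c(=O)n(Cc3ccccc3)c3cccnc32)cc1C(F)(F)F`, reaches only the assay limit of < 500 nM, so for it no number is known, only (the limit of < 500 nM in this assay, at which 1 of the 3 values shown sits).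

Compound 4, `Cc1ccc(-n2c(=O)n(-c3ccc(C#N)c(C(F)(F)F)c3)c3ccccc32)cc1`, is not yet measured. It differs from compound 2 in one place: 4-methylphenyl in place of (pyridin-3-yl)methyl on an aromatic nitrogen. No comparable single change has been measured among the three known compounds, so the size of the step can only be guessed. The step from compound 2 to compound 4 is expected to go downward, a 2.5-fold lower number from compound 2 to compound 4 (0.40 log units; beyond the scatter), beyond the usual scatter. Compound 4 is therefore estimated to give 1000 nM in this assay, within a range from 300 nM to 3000 nM, with a real chance that only the limit is reported.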

Compound 4, solubility: 790 nM
Compound 4: middle estimate off by 1.3-fold (0.10 log units), on the high side, and the stated range covers the measured number.
By their numbers in this assay, from the lowest: compound 4; then compound 2; then compound 1. At a limit, below all of these: compound 3.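

This is the first single change measured among these compounds, and it shows that the group on this aromatic nitrogen matters in this assay: the swap gives a 3.2-fold lower number from compound 2 to compound 4 (0.50 log units; beyond the scatter), a step beyond the usual scatter. The group that leaves holds a ring nitrogen and a hydrogen-bond acceptor, while the group that enters has carbon only in its ring and no acceptor, yet compound 4 still returns a plain number. Compound 3 remains the only compound reported as a limit rather than a number: the limit of < 500 nM in this assay, at which 1 of the 4 values shown sits.

The swap alters both the ring and the way it is attached, so one step cannot show which of these sets the size of the drop. From the compounds shown here alone, how an amine or a carboxylic acid on this nitrogen would read also stays open.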